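The compounds below may be only part of what the source reports. "The series", "measured", "known", "first", "only" and "open" are said of these compounds alone.

Two coumarin-ester compounds have been measured in a functional assay on HT-1080 cells (Homo sapiens), read by transwell migration, with a stated time of 24 h, tested at 1 uM (on this read-out higher numbers stand for a weaker effect at the one concentration tested and lower numbers for a stronger effect), so far. Compound 1, `CC(C)C(=O)OCc1ccc2oc(=O)c(C(=O)Oc3cccc(Br)c3)cc2c1`, gives 37.8% in this assay. Compound 2, `O=C(Oc1ccccc1)c1cc2cc([N+](=O)[O-])ccc2oc1=O`, gives 76.7%; of the two numbers, this is the highest, and the gap to compound 1 lies beyond the scatter, so the effect of compound 2 at the tested concentration is the weaker one. For the measured compounds named here, the two structures differ in several places at once, so no single step between them can be read off.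

Compound 3, `O=C(Oc1cccc(Cl)c1)c1cc2cc([N+](=O)[O-])ccc2oc1=O`, is the next compound to be measured in this assay. It differs from compound 2 in one place: chloro in place of hydrogen on an aromatic carbon. No step of this kind has been measured yet, so the expectation rests only on the two numbers shown. Given that compound 1, which also carries a halogen on its phenoxy ring, gives 37.8%, a moderate step downward, a number 14.7 percentage points lower from compound 2 to compound 3 (beyond the scatter), is expected. On that basis compound 3 is estimated at 62%, with a range from 40% to 85%.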

Compound 3, a percentage reported as activity, at one concentration (the size of the read-out at that concentration, not a potency): 65.8%
Compound 3: middle estimate off by 3.8 percentage points, on the low side; the measured number falls inside the stated range.
By their numbers in this assay, from the lowest: compound 1; then compound 3; then compound 2.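

For the compounds shown here, the change from phenoxy to 3-chlorophenoxy is the first single change that can be read in this assay, and it gives a number 10.9 percentage points lower from compound 2 to compound 3 (beyond the scatter). Since lower numbers stand for a stronger effect here, adding one chlorine atom at this place on the phenoxy ring strengthens the effect at the tested concentration, though only modestly. Nothing shown gives a reason for this step.

On these data alone, it remains open whether the step is specific to chloro or whether other groups at the same place, such as fluoro, methoxy or an amine, would move the number in the same direction or by a similar amount. It is also unknown whether chloro would have the same effect at another place on this ring.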